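Removing a Propanoyl Group from a Melanocortin Receptor Agonist

A few compounds are considered here, and "the series" means these few. Any claim that something is new, unique, unknown or untested is made for them only; others in the source may bear on it.

Compound 1 `CCC(=O)N1C[C@@H](C(=O)N2CCN(c3ccc(C)cc3[C@@H](NC(=O)CCN(C)C)C(C)C)CC2)[C@H](c2ccc(Cl)cc2)C1` was tested in a functional assay on CHO cells with Melanocortin receptor 4 (Homo sapiens) as the target, read by cAMP accumulation (on this read-out lower numbers stand for smaller maximal responses and higher numbers for larger maximal responses), where compound 1 gives 129%. Among the three measured compounds this is the highest number. Compound 2 `CC(C)[C@H](NC(=O)CCN(C)C)c1cccc(F)c1N1CCN(C(=O)[C@@H]2CN(C(C)C)C[C@H]2c2ccc(Cl)cc2)CC1` gives 103% in this assay, a number beyond the scatter below compound 1, and compound 3 `CNCC(=O)N[C@H](c1cc(C)ccc1N1CCN(C(=O)[C@@H]2CN(C3CCOCC3)C[C@H]2c2ccc(Cl)cc2)CC1)C(C)C` gives 84% in this assay, further below still. Compound 4 `Cc1ccc(N2CCN(C(=O)[C@@H]3CNC[C@H]3c3ccc(Cl)cc3)CC2)c([C@@H](NC(=O)CCN(C)C)C(C)C)c1` has not yet been measured. It differs from compound 1 in one place: hydrogen in place of propanoyl on an amine nitrogen in a ring. The propanoyl group leaves and a hydrogen takes its place on an amine nitrogen in a ring. Going by the values given here, no measured pair shows exactly this change, so the size of the step is uncertain. The step of a number 29 percentage points lower from compound 1 to compound 4 (beyond the scatter) is expected to be a moderate drop, in keeping with the lower numbers seen for compound 2 and compound 3, which carry other groups on that nitrogen. Compound 4 is estimated at 100%, within a range from 70% to 130%.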

Compound 4, intrinsic activity: the largest response reached, in percent of the reference agonist's: 72%
Beside the measured number, compound 4's estimate is 28 percentage points above it, and the stated range covers the measured number.
By their numbers in this assay, from the lowest: compound 4; then compound 3; then compound 2; then compound 1.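

In this assay, replacing the propanoyl group with hydrogen on the amine nitrogen in the ring gives a number 57 percentage points lower from compound 1 to compound 4 (beyond the scatter), a large step. Going by these compounds alone, this is the first pair of compounds that differ only at this position, and it shows that the maximal response depends on what this nitrogen carries, at least in this pair. The data offer no explanation for the size of this drop. On these data alone, it remains open whether an acetyl group or a longer butanoyl chain on the same nitrogen would give a response nearer to that of compound 1 or of compound 4.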